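Hydrogen for methyl on the sulfonamide nitrogen of compound 1

A few compounds are considered here, and "the series" means these few. Any claim that something is new, unique, unknown or untested is made for them only; others in the source may bear on it.

Three compounds have numbers in an assay on CHO cells for displacement of a labelled ligand from prostaglandin D2 receptor 2 (Homo sapiens), read by scintillation counting; on this read-out lower numbers stand for stronger inhibition and higher numbers for weaker inhibition. Compound 1 `COCCN(C)S(=O)(=O)c1ccc(C)c(C#Cc2cc(Cl)ccc2OCC(=O)O)c1` gives 4.1 nM. Compound 2 `CCCc1ccncc1C#Cc1cc(Cl)ccc1OCC(=O)O` gives 4.3 nM, a number within the scatter of that of compound 1, and compound 3 `N#Cc1ccc(OCC(=O)O)c(C#Cc2ccccc2Cl)c1` gives 24 nM, a weaker number that lies beyond the scatter. Compound 1 therefore stands at the low end of the three, level with compound 2 and well below compound 3.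

For the measured compounds named here, no pair of measured compounds differs in a single place, so no measured step guides the next change. Compound 4 `COCCNS(=O)(=O)c1ccc(C)c(C#Cc2cc(Cl)ccc2OCC(=O)O)c1` differs from compound 1 by hydrogen in place of methyl on a sulfonamide nitrogen. A hydrogen in place of a methyl at this position is a small change, and the expected step from compound 1 to compound 4 is a 1.2-fold higher number from compound 1 to compound 4 (0.09 log units; within the scatter), nothing beyond the scatter. Compound 4 is estimated at 5 nM, within a range from 2 nM to 13 nM.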

Compound 4, inhibition constant: 3.6 nM
Estimate against measurement, compound 4: 1.4-fold (0.14 log units) above, within the range that was stated.
By their numbers in this assay, from the lowest: compounds 4, 1 and 2 (each within the scatter of the next); then compound 3.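

In this assay, for the compounds shown here, hydrogen in place of methyl on the sulfonamide nitrogen gives a 1.1-fold lower number from compound 1 to compound 4 (0.06 log units; within the scatter), the first step that can be read at a single place. The methyl of the (2-methoxyethyl)(methyl)sulfamoyl group is therefore not required to keep the number at this level, and (2-methoxyethyl)sulfamoyl serves equally well. No evidence on hand accounts for this result.

Still open, as far as these compounds go, is what the 2-methoxyethyl chain itself contributes on this nitrogen. A longer chain, or a chain ending in an amine or a carboxylic acid, would test this.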